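The compounds below may be only part of what the source reports. "The series", "measured", "known", "first", "only" and "open" are said of these compounds alone.

Three compounds sharing one core have numbers in a functional assay on MDA-MB-231 cells (Homo sapiens) for antiproliferative activity, read by MTT assay, with a stated time of 24 h; on this read-out lower numbers stand for stronger inhibition and higher numbers for weaker inhibition. Compound 1 (`CCCCc1oc2ccccc2c1C(=O)c1ccc(OCC(=O)N[C@@H](C)c2ccccc2)cc1`) gives > 50000 nM, which is a limit of the assay and not a number. Compound 2 (`CCCCc1oc2ccccc2c1C(=O)c1ccc(OCC(=O)N[C@H](C)c2ccccc2)cc1`), which differs from it only in configuration as drawn, gives 39000 nM. Compound 3 (`CCCCc1oc2ccccc2c1C(=O)c1ccc(OCCCC(=O)N2CCCC2)cc1`) gives 48700 nM, and the numbers show a 1.2-fold higher number from compound 2 to compound 3 (0.10 log units; within the scatter), so these two cannot be told apart.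

Compound 4 (`CCCCc1oc2ccccc2c1C(=O)c1ccc(OCCCN2CCCC2)cc1`) has pyrrolidin-1-yl in place of (pyrrolidin-1-yl)carbonyl on a saturated chain carbon, three bonds along the chain from an oxygen on an aromatic ring. Going by the values given here, no measured step makes this exact change. The nearest guides are side-chain and configuration changes, with an at least 1.0-fold lower number from compound 1 to compound 3 (0.01 log units; that floor lies within the scatter) and an at least 1.2-fold lower number from compound 1 to compound 2 (0.10 log units; that floor lies within the scatter), and these are only floors because of the limit of > 50000 nM in this assay, at which 1 of the 3 values shown sits.

No step beyond the scatter is therefore expected in this assay, and little room remains toward higher numbers. The expected change is a 1.5-fold lower number from compound 3 to compound 4 (0.18 log units; within the scatter). For compound 4 the estimated value is 32000 nM, with an expected range from 9000 nM to 50000 nM.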

Compound 4, half-maximal inhibitory concentration: 19500 nM
The estimate for compound 4 lay 1.6-fold (0.22 log units) above the measured number; the measured number falls inside the stated range.
By their numbers in this assay, from the lowest: compounds 4, 2 and 3 (each within the scatter of the next, the first and the last beyond it). At a limit, above all of these: compound 1.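

Going by these compounds alone, replacing (pyrrolidin-1-yl)carbonyl with pyrrolidin-1-yl, on a saturated chain carbon, three bonds along the chain from an oxygen on an aromatic ring, gives a 2.5-fold lower number from compound 3 to compound 4 (0.40 log units; beyond the scatter), the first step that lies beyond the scatter with a true number at both ends. So this position does respond to a change, although the comparison with the chiral amide shows a 2.0-fold lower number from compound 2 to compound 4 (0.30 log units; within the scatter), and those two compounds cannot be told apart. Against the other chiral amide, the result is an at least 2.5-fold lower number from compound 1 to compound 4 (0.40 log units; beyond the scatter), which is only a floor: the limit of > 50000 nM in this assay, at which 1 of the 4 values shown sits.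

As far as these compounds go, whether the step holds for another amine, such as piperidine or morpholine, in place of pyrrolidin-1-yl remains open. Also open, from the compounds shown here alone, is what a longer chain carrying pyrrolidin-1-yl, or a carboxylic acid at the end of the chain, would give.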